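Amine for acid on the side chain of compound 2

The compounds below may be only part of what the source reports. "The series", "measured", "known", "first", "only" and "open" are said of these compounds alone.

The series shares one core carrying an amide-linked saturated ring with a side chain and a dihalophenyl group. Compound 1 `Cn1ncc(Cl)c1-c1cc(C(=O)N[C@@H]2CN[C@H](CCO)C[C@H]2c2ccc(F)c(F)c2)oc1Cl` carries a hydroxyethyl chain and a difluorophenyl group; in a functional assay on LNCaP cells (Homo sapiens) for antiproliferative activity (a lower number here means a stronger inhibitor, a higher number a weaker inhibitor), compound 1 gives 60 nM. Compound 2 `Cn1ncc(Cl)c1-c1cc(C(=O)N[C@@H]2CN[C@H](CC(=O)O)C[C@H]2c2ccc(Cl)c(Cl)c2)oc1Cl` carries a carboxymethyl chain and a dichlorophenyl group; in this assay compound 2 gives 640 nM, the highest of the two numbers recorded, with compound 1 the nearest entry at a lower number, a gap beyond the scatter. Compound 3 `CC(=O)OCC[C@@H]1C[C@@H](c2ccc(F)c(F)c2)[C@H](NC(=O)c2cc(-c3c(Cl)cnn3C)c(Cl)o2)CN1`, the acetate ester of the hydroxyethyl chain, has no result in this assay ("not determined" (no result reported)). Compound 1 and compound 2 differ in more than one place, so their gap is not assigned to any single change.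

Compound 4 `CN(C)CC[C@@H]1C[C@@H](c2ccc(Cl)c(Cl)c2)[C@H](NC(=O)c2cc(-c3c(Cl)cnn3C)c(Cl)o2)CN1` is to be measured in this assay. It differs from compound 2 in one place: (dimethylamino)methyl in place of carboxy on a saturated chain carbon bound to a saturated ring carbon. Going by the values given here, no measured pair shows this change. For compound 4 a move to a lower number is expected, of a size beyond the scatter, because compound 1, the only entry with a chain carrying neither carboxy nor a charge-bearing group, gives 60 nM. The expected step from compound 2 to compound 4 is a 5.3-fold lower number from compound 2 to compound 4 (0.73 log units; beyond the scatter). Compound 4 is estimated at 120 nM, in the range 35 nM to 450 nM.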

Compound 4, half-maximal inhibitory concentration: 1930 nM
Compound 4: middle estimate off by 16-fold (1.21 log units), on the low side; the whole stated range lies below it.
By their numbers in this assay, from the lowest: compound 1; then compound 2; then compound 4.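

Going by these compounds alone, with the shared core and the dichlorophenyl group held constant, carboxymethyl to 2-(dimethylamino)ethyl gives in this assay a 3.0-fold higher number from compound 2 to compound 4 (0.48 log units; beyond the scatter), the first single-place step, and it runs towards a weaker inhibitor. At this saturated chain carbon bound to a saturated ring carbon, the group at the chain end therefore changes the read-out by a modest amount beyond the scatter, and losing carboxy in favour of (dimethylamino)methyl brings no gain in this assay. No measurement of any property of these compounds bears on this step, so the data offer no explanation for it.

Open, as far as these compounds go, is how a primary amine or a primary amide at the end of this chain would stand against carboxy and (dimethylamino)methyl with the dichlorophenyl group kept in place. Also open, from the compounds shown here alone, is how much of the lower number of compound 1 belongs to its hydroxyethyl chain and how much to its difluorophenyl group, since compound 1 differs from the dichlorophenyl compounds in more than one place; a hydroxyethyl chain paired with the dichlorophenyl group would separate the two.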